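The compounds below may be only part of what the source reports. "The series", "measured", "known", "first", "only" and "open" are said of these compounds alone.

Among the measured compounds shown here, in a functional assay on SGC-7901 cells (Homo sapiens) for antiproliferative activity, read by MTT assay, with a stated time of 24 h (a higher number here means a weaker inhibitor, a lower number a stronger inhibitor), compound 3 `Cc1ccccc1C(=O)NNC(=O)c1ccccc1NS(=O)(=O)c1cnc(O)nc1O` gives 13000 nM, the only true number in this small series. Compound 1 `O=C(NNc1ccccc1F)c1ccccc1NS(=O)(=O)c1cnc(O)nc1O` gives > 20000 nM, which is a limit and not a number. Compound 2 `O=C(NNc1ccc(F)cc1)c1ccccc1NS(=O)(=O)c1cnc(O)nc1O` gives > 20000 nM, which is also a limit.

The next compound, compound 4 `O=C(NNC(=O)c1ccccc1NS(=O)(=O)c1cnc(O)nc1O)c1cccc(Cl)c1`, keeps everything in compound 3 except one group: 3-chlorophenyl stands in place of 2-methylphenyl on a carbonyl carbon (3-chlorophenyl in place of 2-methylphenyl on a carbonyl carbon).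

Two measured steps lead to compound 3: an at least 1.5-fold lower number from compound 1 to compound 3 (0.18 log units; that floor lies within the scatter) and an at least 1.5-fold lower number from compound 2 to compound 3 (0.18 log units; that floor lies within the scatter). Both change the group on an amine nitrogen, and neither exchanges one group on the carbonyl carbon for another. They therefore set no size for this new step, and the best guide is the value of compound 3, 13000 nM. No change beyond the scatter is expected in this assay, and the estimated step is a 1.1-fold lower number from compound 3 to compound 4 (0.03 log units; within the scatter). For compound 4 the expected value is 12000 nM, within an estimated range of 4000 nM to 30000 nM.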

Compound 4, half-maximal inhibitory concentration: 1820 nM
The estimate for compound 4 lay 6.6-fold (0.82 log units) above the measured number, outside the stated range (below it).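

Among the compounds shown here, the group on the carbonyl carbon clearly matters in this assay: 3-chlorophenyl in place of 2-methylphenyl gives a 7.1-fold lower number from compound 3 to compound 4 (0.85 log units; beyond the scatter), a change of the aryl group alone and the first step with a readable size beyond the scatter. Compound 4 also stands well clear of the two compounds that carry a fluorophenyl directly on the amine nitrogen, with an at least 10-fold lower number from compound 2 to compound 4 (1.04 log units; beyond the scatter) and an at least 10-fold lower number from compound 1 to compound 4 (1.04 log units; beyond the scatter). These two steps are only floors, since their true sizes stay hidden because compound 1 and compound 2 both sit at a limit: the limit of > 20000 nM in this assay, at which 2 of the 4 values shown sit.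

This single exchange moves the methyl to chlorine and changes the ring position at once, so the compounds shown cannot say which of the two matters. Either 3-methylphenyl or 2-chlorophenyl on the same carbonyl carbon would separate them.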